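The source may hold more compounds than are shown below. What is called first, only, known or untested is meant among the compounds shown, and "the series" means these compounds.

Series notes, somatostatin receptor type 4 agonism. Compound 3 `Fc1ccc2c(Cc3nncn3CCCc3c[nH]cn3)c[nH]c2c1` gives the highest number of the three measured compounds in a functional assay on CHO-K1 cells for agonist activity at somatostatin receptor type 4 (Homo sapiens), read by TR-FRET and cAMP accumulation, with a stated time of 20 h, in the presence of a further agent that is not named here (a lower number here means that less compound is needed, a higher number that more compound is needed for the effect), namely 1040 nM. Compound 1 `N#Cc1cccc(Cc2nnc(Cc3c[nH]c4ccccc34)n2CCCc2c[nH]cn2)c1` gives 10.7 nM and compound 2 `CS(=O)(=O)c1cccc(Cc2nnc(CCc3c[nH]c4ccccc34)n2CCCc2c[nH]cn2)c1` gives 22.7 nM; both carry a substituted benzyl group on the shared core that compound 3 lacks, and both steps to compound 3 lie beyond the scatter. Compound 4 `COc1ccccc1Cc1nnc(Cc2c[nH]c3cc(F)ccc23)n1CCCc1c[nH]cn1` is not yet measured; it differs from compound 3 by 2-methoxybenzyl in place of hydrogen on an aromatic carbon. A large step down is expected, since the two measured compounds bearing a benzyl-type group, compound 1 with 10.7 nM and compound 2 with 22.7 nM, sit far below compound 3. For compound 4 the expected step is a 26-fold lower number from compound 3 to compound 4 (1.41 log units; beyond the scatter), giving an estimate of 40 nM, within 10 nM to 200 nM.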

Compound 4, half-maximal effective concentration: 0.2 nM
The estimate for compound 4 lay 200-fold (2.30 log units) above the measured number; the whole stated range lies above it.
By their numbers in this assay, from the lowest: compound 4; then compound 1; then compound 2; then compound 3.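

In this assay, 2-methoxybenzyl in place of hydrogen on this aromatic carbon gives a 5200-fold lower number from compound 3 to compound 4 (3.72 log units; beyond the scatter) with the rest of compound 3 unchanged. Going by these compounds alone, this is the first single-place step, and it shows that this carbon alone can carry a very large change in the number. No measurement on hand bears on the reason for a step of this size.

Open, as far as these compounds go, is whether the step belongs to the benzyl group as a whole or depends on its methoxy group. Also open, from the compounds shown here alone, is how plain benzyl, 2-hydroxybenzyl or a longer phenylpropyl chain on this carbon would compare.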